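Chlorophenyl position on the butyl-bearing core

The source may hold more compounds than are shown below. What is called first, only, known or untested is meant among the compounds shown, and "the series" means these compounds.

Compound 1 `Cc1nn(C)c2c1C(c1cccc(Cl)c1)=NCC(=O)N2`: > 40 mg/kg (a limit)
Compound 2 `CCCCn1nc(C)c2c1NC(=O)CN=C2c1ccccc1Cl`: 40 mg/kg

For the measured compounds named here, in a functional assay on the whole organism (strain Holtzman) with Rattus norvegicus as the target (on this read-out higher numbers stand for an effect only at larger amounts of compound and lower numbers for an effect already at smaller amounts), compound 2 gives 40 mg/kg, the only number in the set. For compound 1 the result is a limit of the assay, > 40 mg/kg; compound 1 thus accounts for (the limit of > 40 mg/kg in this assay, at which 1 of the 2 values shown sits). Compound 3 `CCCCn1nc(C)c2c1NC(=O)CN=C2c1cccc(Cl)c1` is not yet measured and differs from compound 2 in one place: 3-chlorophenyl in place of 2-chlorophenyl on a carbon with a double bond to nitrogen. Going by the values given here, no step between measured compounds is known, so no size can be read off. The expected step of a 1.5-fold higher number from compound 2 to compound 3 (0.18 log units; within the scatter) is a lean toward larger amounts, not clearly beyond the scatter. Compound 3 is estimated at 60 mg/kg in this assay, between 30 mg/kg and 150 mg/kg.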

Compound 3, minimum effective dose: > 40 mg/kg
Compound 3: no number, only a limit; the forecaster's own chance of this, stated with the estimate: 50%; the middle value lies beyond the limit too.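

In this assay, 3-chlorophenyl in place of 2-chlorophenyl on the carbon with a double bond to nitrogen gives a number no lower from compound 2 to compound 3 (the limit leaves the size open), so this change at this position brings no shift toward smaller amounts on the butyl-bearing core. Compound 3 gives > 40 mg/kg, which is a limit of the assay. The step between compound 1 and compound 3 cannot be read, since both values are limits: the limit of > 40 mg/kg in this assay, at which 2 of the 3 values shown sit.

Going by these compounds, how far compound 3 lies from compound 2 remains open. Also open, on these data alone, is whether 4-chlorophenyl or an unsubstituted phenyl at this position, or a longer chain in place of butyl, would give an effect at smaller amounts.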